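The source may hold more compounds than are shown below. What is called first, only, known or untested is meant among the compounds shown, and "the series" means these compounds.

Measured so far:
Compound 1, `O=C(CCC1=CCN(CCCc2ccc(Br)cc2)C1=O)NO`: 2200 nM
Compound 2, `O=C(CCC1=CCN(Cc2ccc(Br)cc2F)C1=O)NO`: 4280 nM

Both compounds were tested in a functional assay on NUGC-3 cells (Homo sapiens) for inhibition, read by sulforhodamine B assay; a higher number here means a weaker inhibitor of growth, a lower number a stronger inhibitor of growth. Compound 1 gives 2200 nM there, and compound 2 gives 4280 nM; these two numbers lie within the usual scatter of each other, so on the evidence shown the two compounds cannot be told apart, and compound 1 stands simply as one of two similar results.

Compound 3, `Cc1ccc(CCCN2CC=C(CCC(=O)NO)C2=O)cc1`, has not yet been measured in this assay. It differs from compound 1 in one place: methyl in place of bromo on an aromatic carbon. Cut one bond further out, this reads as 4-bromophenyl turning into 4-methylphenyl. For the measured compounds named here, no measured pair shows what such a swap does here, so the expectation rests on the size of the group alone. The step of a 1.2-fold higher number from compound 1 to compound 3 (0.07 log units; within the scatter) is expected to be small, most likely none beyond the scatter. Compound 3 is therefore estimated at 2600 nM, within a range from 1000 nM to 7000 nM.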

Compound 3, concentration for 50% growth inhibition: 2200 nM
Compound 3: the middle estimate sits 1.2-fold (0.07 log units) above what was measured, and the stated range covers the measured number.
By their numbers in this assay, from the lowest: compounds 1, 3 and 2 (each within the scatter of the next).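

In this assay, methyl in place of bromo on the aromatic carbon gives no change at the digits printed from compound 1 to compound 3 (within the scatter). For the compounds shown here, this is the first comparison here in which only one place differs, and it shows that, in this pair, the bromine can be exchanged for a methyl without a measurable shift in growth inhibition. The pair shows only that these two groups read alike at this position, and no other measurement shown speaks to why.

From the compounds shown here alone, whether an amine, a carboxylic acid or a longer chain at this same position would also leave the number in place remains open. So does what a plain hydrogen there would do, with no substituent on that ring carbon at all.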